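The source may report more compounds than this note shows. Statements on the series, on what has been measured and on what is new or still open speak of the compounds shown alone.

Measured compounds:
compound 1 `Nc1scc(CN2CCN(c3cc(Cl)cc(Cl)c3)CC2)c1C(=O)c1ccc(Cl)cc1`: 1%
compound 2 `Nc1scc(CN2CCN(c3ccc(F)cc3Cl)CC2)c1C(=O)c1ccc(Cl)cc1`: 0%
compound 3 `Nc1scc(CN2CCN(C3CCCC3)CC2)c1C(=O)c1ccc(Cl)cc1`: 3%

In an assay on CHO cells for displacement of a labelled ligand from adenosine receptor A3 (Homo sapiens), read by scintillation counting, with a stated time of 120 min, tested at 10 uM (a higher number here means more inhibition at the concentration tested (going by the name of the read-out), a lower number less inhibition), all three measured compounds give very small numbers. Of the three, compound 3 has the largest figure, but the steps of a number 2 percentage points higher from compound 1 to compound 3 (within the scatter) and a number 3 percentage points higher from compound 2 to compound 3 (within the scatter) are both within the scatter, so compound 3 is not told apart from compound 1 or compound 2 on these data.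

Compound 4 `Nc1scc(CN2CCN(c3ccc(F)c(Cl)c3)CC2)c1C(=O)c1ccc(Cl)cc1` is not yet measured. It differs from compound 3 as follows: 3-chloro-4-fluorophenyl in place of cyclopentyl on an amine nitrogen in a ring. For the measured compounds named here, the steps that bear on this change run in the opposite direction, where an aryl group on the same ring nitrogen is replaced by cyclopentyl: a number 2 percentage points higher from compound 1 to compound 3 (within the scatter) and a number 3 percentage points higher from compound 2 to compound 3 (within the scatter). The exchange of one aryl group for another, a number 1 percentage points lower from compound 1 to compound 2 (within the scatter), is likewise within the scatter. Going by the values given here, nothing among the measured compounds points to a step beyond the scatter, and so the expected step of a number 1 percentage points lower from compound 3 to compound 4 (within the scatter) is small. Compound 4 is therefore estimated at 2% in this assay, with a range from -8% to 12%.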

Compound 4, a percentage reported as inhibition, at one concentration (the size of the read-out at that concentration, not a potency): 0%
Beside the measured number, compound 4's estimate is 2 percentage points above it; the range from low to high includes it.
By their numbers in this assay, from the lowest: compounds 2, 4, 1 and 3 (each within the scatter of the next).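

In this assay, 3-chloro-4-fluorophenyl on the amine nitrogen in the ring gives a number 3 percentage points lower from compound 3 to compound 4 (within the scatter), so this further aromatic ring, with its larger count of heavy atoms, is not told apart from cyclopentyl. The other two steps, no change at the digits printed from compound 2 to compound 4 (within the scatter) and a number 1 percentage points lower from compound 1 to compound 4 (within the scatter), extend this to a third halogen pattern on the phenyl ring, and none of the three patterns is told apart from the others at this position. No measurement shown offers a reason for this flat picture.

The compounds leave open whether an amine, a carboxylic acid or a longer chain on this ring nitrogen would give a step beyond the scatter. They also leave open whether any change elsewhere on the shared core would do so, and with every number this small, any real effect of the group at this position remains unseen.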